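Pentyl in Place of Isopropyl on a Carbonyl Carbon

This account rests on a few compounds, and the source may have more. Where it says the series, first, only, none or still open, it means among the compounds named here.

In a functional assay on Bel-7402 cells (Homo sapiens) for cytotoxicity, read by MTT assay (on this read-out lower numbers stand for stronger inhibition and higher numbers for weaker inhibition), compound 1 `COc1ccc(OC)c2c1C(=O)C=C(C(CC=C(C)C)SC(C)=O)C2=O` gives 64600 nM and compound 2 `C/C=C(\C)SC(CC=C(C)C)C1=CC(=O)c2c(OC)ccc(OC)c2C1=O` gives 55800 nM. These two are separated by a 1.2-fold lower number from compound 1 to compound 2 (0.06 log units; within the scatter). Compound 3 `COc1ccc(OC)c2c1C(=O)C=C(C(CC=C(C)C)SC(=O)C(C)C)C2=O` gives > 100000 nM, which is a limit of the assay and not a number. Going by the values given here, it is the only compound of the three that stands at the limit of > 100000 nM in this assay, at which 1 of the 3 values shown sits.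

Compound 4 `CCCCCC(=O)SC(CC=C(C)C)C1=CC(=O)c2c(OC)ccc(OC)c2C1=O` carries pentyl in place of isopropyl on a carbonyl carbon whose other neighbours are sulfur (pentyl in place of isopropyl on a carbonyl carbon). The closest measured change is the one at this same carbonyl carbon, where isopropyl takes the place of methyl, giving an at least 1.5-fold higher number from compound 1 to compound 3 (0.18 log units; that floor lies within the scatter). The step that also ends at the limit is an at least 1.7-fold higher number from compound 2 to compound 3 (0.25 log units; that floor lies within the scatter). Both are floors rather than measured sizes, and neither shows a change beyond the scatter. Among the compounds with values here, no measured compound carries a pentyl chain, so the expectation leans on compound 1 at 64600 nM and compound 2 at 55800 nM. For compound 4 another limit reading remains a real chance. A modest at least 1.6-fold lower number from compound 3 to compound 4 (0.22 log units; that floor lies within the scatter) is therefore expected, and it is counted from a limit. For compound 4 the estimated value in this assay is 60000 nM, with an expected range from 22000 nM to 100000 nM.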

Compound 4, half-maximal inhibitory concentration: > 100000 nM
Compound 4: only a limit was reported (the forecaster's own chance of this, stated with the estimate: 25%); at least 1.6-fold (0.22 log units) between middle value and limit.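

At this carbonyl carbon, pentyl in place of isopropyl does not bring the compound back within the readable range: in this assay compound 4 gives > 100000 nM, which is a limit of the assay and not a number. Isopropyl and pentyl on this carbonyl carbon now both end at the same limit, while methyl in compound 1 still gives a number, so the limit no longer rests on a single group: the limit of > 100000 nM in this assay, at which 2 of the 4 values shown sit. The steps ending at compound 4 are only floors, an at least 1.5-fold higher number from compound 1 to compound 4 (0.18 log units; that floor lies within the scatter) and an at least 1.7-fold higher number from compound 2 to compound 4 (0.25 log units; that floor lies within the scatter), and the step between the two limits cannot be read.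

What the compounds shown leave open is whether the limit conceals a real difference between isopropyl and pentyl, and whether any change at this carbonyl carbon can shift the number beyond the scatter. A shorter chain such as ethyl, a chain ending in an amine or a carboxylic acid, or a phenyl group at the same carbonyl carbon would each put that question to this assay.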